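Hydrazone series: aryl swap on the hydrazine end

This account rests on a few compounds, and the source may have more. Where it says the series, first, only, none or still open, it means among the compounds named here.

Measured so far:
compound 1 `CC(=O)/C(=N\Nc1ccccc1C)Oc1cccc(Cl)c1` — > 10000 nM
compound 2 `CC(=O)/C(=N\c1cccc(Cl)c1)NNc1ccc(C)cc1` — 2290 nM

In an assay on isolated protein for binding affinity to corticotropin-releasing factor receptor 1 (Homo sapiens) (on this read-out lower numbers stand for stronger inhibition and higher numbers for weaker inhibition), compound 1 reaches only the assay limit of > 10000 nM. Compound 2 gives 2290 nM in this assay. Among the measured compounds shown here, compound 2 thus holds the only number in the set. The remaining value belongs to compound 1 and is a limit of the assay (the limit of > 10000 nM in this assay, at which 1 of the 2 values shown sits). Compound 3 `CC(=O)/C(=N\c1cccc(Cl)c1)NNc1ccc(Br)cc1` differs from compound 2 by one change: bromo in place of methyl on an aromatic carbon, on an aromatic carbon of a six-membered aromatic ring of carbon only, para to a large group. For the measured compounds named here, no step between measured compounds is available to size this change. Compound 3 is expected near compound 2, with a step of a 1.1-fold lower number from compound 2 to compound 3 (0.06 log units; within the scatter) that stays within the usual scatter. The estimate for compound 3 is 2000 nM, range 700 nM to 6000 nM.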

Compound 3, inhibition constant: 1460 nM
Estimate against measurement, compound 3: 1.4-fold (0.14 log units) above, within the range that was stated.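

On the hydrazine end, 4-methylphenyl and 4-bromophenyl read alike in this assay, with a 1.6-fold lower number from compound 2 to compound 3 (0.20 log units; within the scatter). This first readable step shows that at this place, para to a large group, bromo in place of methyl leaves the read-out within the scatter. Nothing measured here bears on a cause for this step.

The result for compound 1 is a limit, so steps involving it cannot be read. From the compounds shown here alone, how an amine or a carboxylic acid would read at this place remains open.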